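Replacing the ortho fluoro of compound 1 with a 2-hydroxyethyl group

This account rests on a few compounds, and the source may have more. Where it says the series, first, only, none or still open, it means among the compounds named here.

Compound 1 `CC1CC/C(=N\Nc2ccccc2F)c2ncc(C(=O)O)c(=O)n21` stands highest of the three measured compounds in a functional assay on the whole organism for inhibition, with Rattus norvegicus as the target (a lower number here means that less compound is needed, a higher number that more compound is needed for the effect), where compound 1 gives 5 umol/kg. Its nearest neighbour is compound 3 `CC1CC/C(=N\Nc2ccc(O)cc2)c2ncc(C(=O)O)c(=O)n21`, which in this assay gives 1.7 umol/kg, reached by a 2.9-fold lower number from compound 1 to compound 3 (0.47 log units; beyond the scatter). The furthest is compound 2 `CC1CC/C(=N\Nc2ccc(Br)cc2)c2ncc(C(=O)O)c(=O)n21`, which in this assay gives 0.8 umol/kg, reached by a 6.3-fold lower number from compound 1 to compound 2 (0.80 log units; beyond the scatter); between them lies a 2.1-fold higher number from compound 2 to compound 3 (0.33 log units; beyond the scatter).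

Compound 4 `CC1CC/C(=N\Nc2ccccc2CCO)c2ncc(C(=O)O)c(=O)n21` differs from compound 1 by 2-hydroxyethyl in place of fluoro on an aromatic carbon. Within the data shown here, both measured steps from compound 1 exchange the fluoro for a substituent on another carbon of the same ring, so neither bears directly on a change at the position the fluoro occupies; they show only that moving away from compound 1 has so far lowered the number by modest amounts. Among the measured compounds shown here, with no close precedent, the step is expected to be small, at most modest, and more likely toward a lower number: a 1.3-fold lower number from compound 1 to compound 4 (0.10 log units; within the scatter). Compound 4 is therefore estimated at 4 umol/kg in this assay, within a range from 1.5 umol/kg to 12 umol/kg.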

Compound 4, dose for 50% inhibition: 10.8 umol/kg
Compound 4: middle estimate off by 2.7-fold (0.43 log units), on the low side; the measured number falls inside the stated range.
By their numbers in this assay, from the lowest: compound 2; then compound 3; then compound 1; then compound 4.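

In this assay, the step at this aromatic carbon, ortho to a large group, is a 2.2-fold higher number from compound 1 to compound 4 (0.33 log units; beyond the scatter). Among these compounds, it is the only step from compound 1 that gives a higher number, and the only one that changes the substituent at this carbon without placing a new one elsewhere on the ring, so replacing the fluoro with 2-hydroxyethyl here carries a modest cost rather than the modest gains seen with compound 2 and compound 3. No measurement at hand bears on why the number rose.

As far as these compounds go, what remains open is whether the rise belongs to the length of the chain or to its terminal hydroxy, which an ethyl or 2-methoxyethyl group on the same carbon would separate. Also open, from the compounds shown here alone, is how a shorter hydroxymethyl, a longer 3-hydroxypropyl chain or a 2-aminoethyl group would behave at this position.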